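The source may report more compounds than this note shows. Statements on the series, on what has been measured and on what is new or still open speak of the compounds shown alone.

Measured so far:
compound 1, `CS/C(=N\C(=O)c1ccco1)NC(=O)c1ccco1`, in an ADME assay on MCF-10A cells (Homo sapiens) for cytotoxicity, read by MTT assay, with a stated time of 72 h (on this read-out lower numbers stand for stronger inhibition of growth and higher numbers for weaker inhibition of growth), gives 8220 nM
compound 3, `CS/C(=N\C(=O)c1cccs1)NC(=O)c1cccs1`, in this assay gives 19700 nM
compound 2, `O=C(/N=C(/NC(=O)c1cccs1)[Se]Cc1ccccc1)c1cccs1`, in this assay gives 72500 nM

Compound 1 shows the lowest number of the three, so among them it inhibits the growth of these cells most strongly. Compound 1 and compound 3 share the same kind of build but rest on different cores; the difference between the two cores is not broken down here. Compound 3 and compound 2 share one core and differ in one place: a group of 8 heavy atoms (7 carbon, 1 selenium; one six-membered aromatic ring of carbon only) in place of a group of 2 heavy atoms (1 carbon, 1 sulfur; no ring), on a carbon with a double bond to nitrogen. That change gave a 3.7-fold higher number from compound 3 to compound 2 (0.57 log units; beyond the scatter), so the larger group made the number climb.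

Compound 4, `O=C(/N=C(/NC(=O)c1ccco1)[Se]Cc1ccccc1)c1ccco1`, has not yet been measured. It stands to compound 1 exactly as compound 2 stands to compound 3: a group of 8 heavy atoms (7 carbon, 1 selenium; one six-membered aromatic ring of carbon only) in place of a group of 2 heavy atoms (1 carbon, 1 sulfur; no ring), on a carbon with a double bond to nitrogen. The place is the same in both cases, so this is the same change made on the other core. Among the measured compounds shown here, only the one measured example of it exists, so the expectation rests on that alone. From compound 1 to compound 4 a step of about a 3.6-fold higher number from compound 1 to compound 4 (0.56 log units; beyond the scatter) is expected in this assay, in line with a 3.7-fold higher number from compound 3 to compound 2 (0.57 log units; beyond the scatter). Compound 4 is therefore estimated at 30000 nM, likely between 15000 nM and 65000 nM.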

Compound 4, concentration for 50% growth inhibition: 8800 nM
The estimate for compound 4 lay 3.4-fold (0.53 log units) above the measured number; measured number below the stated range.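

In this assay the same change, with methylsulfanyl leaving and the larger selenium-bearing group entering, gave a 1.1-fold higher number from compound 1 to compound 4 (0.03 log units; within the scatter) on the core of compound 1. Its size therefore did not carry over from one core to the other, so a step measured on one core is a poor guide to the same step on the other: the same change on two cores in this assay, a 3.7-fold higher number (0.57 log units; beyond the scatter) from compound 3 to compound 2 and a 1.1-fold higher number (0.03 log units; within the scatter) from compound 1 to compound 4, 3.4-fold (0.54 log units) apart, beyond the scatter of two such steps. Among the compounds shown here, this shows that the core matters to the outcome of this change, but with only one pair on each core it does not show why the two cores differ, or which step is more typical of the series.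

The entering group also brings selenium and a six-membered aromatic ring together, so the compounds shown cannot separate the part played by each; a methyl group on selenium, or the same ring carried through sulfur, would be needed for that. On these data alone, how an amine or a longer carbon chain would behave at this place on either core also remains open.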